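Swapping the sulfonyl ring substituent on compound 1

This account rests on a few compounds, and the source may have more. Where it says the series, first, only, none or still open, it means among the compounds named here.

Compound 1, with the structure `CC(C)COc1ncc(-c2cc(F)c(-c3nnc(S(=O)(=O)CC4CC4)[nH]3)cc2F)cc1Cl`, is tested in an ADME assay on microsomes from liver (Homo sapiens) for metabolic stability (a lower number here means slower removal, a higher number faster removal of the compound), where compound 1 gives 67 uL/min. Among the two numbers reported, compound 1 stands highest, though compound 2, `COc1cc(-c2nnc(S(=O)(=O)C3CCC3)[nH]2)ccc1-c1cnc(OCC(C)C)c(Cl)c1`, gives 59 uL/min, which lies within the scatter of compound 1. Compound 3, `O=S(=O)(CC1CC1)c1nnc(-c2cc(F)c(-c3cnc(Oc4ccc(F)cc4F)c(Cl)c3)cc2F)[nH]1`, gives only a limit of the assay, < 14 uL/min, as noted in the limit of < 14 uL/min in this assay, at which 1 of the 3 values shown sits. For the measured compounds named here, the one measured step with a single structural change, an at least 4.7-fold lower number from compound 1 to compound 3 (0.67 log units; beyond the scatter), alters a group on an oxygen on an aromatic ring and so does not touch the part of the molecule changed here.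

Compound 4, `CC(C)COc1ncc(-c2cc(F)c(-c3nnc(S(=O)(=O)C4CCC4)[nH]3)cc2F)cc1Cl`, differs from compound 1 by cyclobutyl in place of cyclopropylmethyl on a sulfonyl sulfur. Going by the values given here, no measured step in this set changes a group on the sulfonyl sulfur, so nothing directly tells how this swap moves the number. Compound 2 does carry a cyclobutyl on its sulfonyl sulfur, and its value sits within the scatter of compound 1, but compound 2 also differs elsewhere, so its comparison with compound 1 is not clean.

Among the compounds with values here, with no bearing step, compound 4 is expected to show a change of a 1.1-fold lower number from compound 1 to compound 4 (0.03 log units; within the scatter), within the scatter. The estimate for compound 4 in this assay is 62 uL/min, between 35 uL/min and 110 uL/min.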

Compound 4, intrinsic clearance in a liver preparation (reported as CLH), per the amount of preparation that the assay uses: 53 uL/min
Compound 4: the middle estimate sits 1.2-fold (0.07 log units) above what was measured, within the range that was stated.
By their numbers in this assay, from the lowest: compounds 4, 2 and 1 (each within the scatter of the next). At a limit, below all of these: compound 3.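

For the compounds shown here, this is the first measured step that changes only the group on the sulfonyl sulfur. In this assay, placing cyclobutyl where cyclopropylmethyl stood gives a 1.3-fold lower number from compound 1 to compound 4 (0.10 log units; within the scatter), so on the core of compound 1, these two carbon-only ring groups, each with 4 heavy atoms, cannot be told apart in this assay. This reading is limited to this one pair, and nothing measured here bears on why the two groups read alike.

The compounds shown leave open whether a group of a different kind on the sulfonyl sulfur, such as a plain methyl, a longer chain, an amine or a carboxylic acid, would move the number beyond the scatter. Going by these compounds, it is also open whether the swap from cyclopropylmethyl to cyclobutyl would read the same on the background of compound 3, which carries 2,4-difluorophenyl on the oxygen instead of isobutyl.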